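Trimming the Hexyl Chain of Compound 2

This account rests on a few compounds, and the source may have more. Where it says the series, first, only, none or still open, it means among the compounds named here.

Going by the values given here, in a functional assay on RAW264.7 cells (Mus musculus) for inhibition, read by Griess assay, with stated times of 1 h and 24 h (a lower number here means a stronger inhibitor, a higher number a weaker inhibitor), compound 2 (`CCCCCCOc1ccc(C(O)C2OC(=O)c3c(OC)cc(OC)cc32)cc1`) gives 5360 nM, the only true number available so far. Among the compounds with values here, its sole comparison, compound 1 (`CCOc1ccc(C(O)C2OC(=O)c3c(OC)cc(OC)cc32)cc1`), reads > 10000 nM, and this is a limit of the assay rather than a number.

The next molecule is compound 3 (`CCC(C)Oc1ccc(C(O)C2OC(=O)c3c(OC)cc(OC)cc32)cc1`). The change is sec-butyl in place of hexyl on an oxygen on an aromatic ring, which means sec-butyl in place of hexyl on an oxygen on an aromatic ring.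

Within the data shown here, only one measured step bears on this change. It is the step of an at least 1.8-fold lower number from compound 1 to compound 2 (0.27 log units; that floor lies within the scatter), made by butyl in place of hydrogen on a saturated chain carbon. That step gives only a floor for the size of the shift, so it offers weak guidance. Compound 3 partly reverses that lengthening, since sec-butyl is the shorter chain, so a small move toward a higher number is expected, perhaps not much beyond the scatter. The expected change is a 1.7-fold higher number from compound 2 to compound 3 (0.23 log units; within the scatter). Compound 3 could also end up as a limit rather than a number. For compound 3 the estimated value is 9000 nM, within an expected range of 4000 nM to 20000 nM.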

Compound 3, half-maximal inhibitory concentration: > 10000 nM
Compound 3 gave a limit, no number; the forecaster's own chance of this, stated with the estimate: 50%; at least 1.1-fold (0.04 log units) between middle value and limit.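

In this assay the swap of hexyl for sec-butyl on this oxygen gives an at least 1.8-fold higher number from compound 2 to compound 3 (0.27 log units; that floor lies within the scatter) and so the change can be sized only from below, with a floor that does not clear the usual scatter of the assay. Going by these compounds alone, compound 3 reads > 10000 nM and this is a limit of the assay, not a number, so compound 2 stays the only compound here with a true number, and the hexyl chain is the only group on this oxygen that has given one. The step between compound 1 and compound 3 cannot be read, since both sit at the same limit, and these two compounds cannot be ranked against each other: the limit of > 10000 nM in this assay, at which 2 of the 3 values shown sit.

With only sec-butyl and ethyl as the shorter groups, chain length and branching cannot be told apart, and a straight butyl chain on this oxygen would be the direct test of that. The compounds shown also leave open whether a longer chain, such as octyl, would give a lower number than compound 2 does.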